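The source may hold more compounds than are shown below. What is called first, only, known or untested is meant among the compounds shown, and "the series" means these compounds.

Measured so far in a functional assay on MCF7 cells (Homo sapiens) for antiproliferative activity, read by sulforhodamine B assay, with a stated time of 48 h; a lower number here means a stronger inhibitor, a higher number a weaker inhibitor:
- compound 1 `O=C1NCCN1c1ccc(S(=O)(=O)Nc2cccc(Br)c2)cc1`: 100 nM
- compound 2 `CCc1ccc(NS(=O)(=O)c2ccc(N3CCNC3=O)cc2)cc1`: 810 nM
- compound 3 `Cc1cccc(NS(=O)(=O)c2ccc(N3CCNC3=O)cc2)c1C`: 230 nM

Compound 2 stands at the highest number of the three. Its gap to the nearest compound is shown by a 3.5-fold lower number from compound 2 to compound 3 (0.55 log units; beyond the scatter), and its gap to the furthest by an 8.1-fold higher number from compound 1 to compound 2 (0.91 log units; beyond the scatter), so both neighbours lie beyond the scatter on the lower side.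

Compound 4 `CCCCCCOc1ccc(NS(=O)(=O)c2ccc(N3CCNC3=O)cc2)cc1` is not yet measured. Its change from compound 2 is hexyloxy in place of ethyl on an aromatic carbon. The two steps that touch compound 2 bear on it: an 8.1-fold higher number from compound 1 to compound 2 (0.91 log units; beyond the scatter) and a 3.5-fold lower number from compound 2 to compound 3 (0.55 log units; beyond the scatter), both modest, both pointing to the group on the sulfonamide nitrogen as the part that moves the number. Among the compounds with values here, neither step exchanges one group for another at the same place on that ring, so there is no direct precedent for the change to compound 4. The expectation is therefore a step that stays within or only a little beyond the scatter, direction not fixed, written as a 1.2-fold lower number from compound 2 to compound 4 (0.06 log units; within the scatter).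

For compound 4 the estimate in this assay is 700 nM, with a range from 200 nM to 2500 nM.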

Compound 4, half-maximal inhibitory concentration: > 1000 nM
Compound 4 gave a limit, no number; the forecaster's own chance of this, stated with the estimate: 5%; middle value at least 1.4-fold (0.15 log units) away from the limit.
By their numbers in this assay, from the lowest: compound 1; then compound 3; then compound 2. At a limit, above all of these: compound 4.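

In this assay compound 4 reads > 1000 nM, which is a limit and not a number. The step of an at least 1.2-fold higher number from compound 2 to compound 4 (0.09 log units; that floor lies within the scatter) sets only a floor, so hexyloxy in place of ethyl on this aromatic carbon, para to a large group, shows no gain, while a real loss remains unproven. This is the first change in the series confined to this one carbon, and its only reading is a limit: the limit of > 1000 nM in this assay, at which 1 of the 4 values shown sits.

From the compounds shown here alone, how far the true value of compound 4 lies from that limit stays open. Also open, going by these compounds, is whether the ether oxygen or the chain length governs the result at this position, a question that a methoxy group and an unbranched hexyl chain on the same carbon would separate.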